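A few compounds are considered here, and "the series" means these few. Any claim that something is new, unique, unknown or untested is made for them only; others in the source may bear on it.

In a functional assay (aorta) for inhibition, with Rattus norvegicus as the target, with a stated time of 8 days (on this read-out higher numbers stand for weaker inhibition and lower numbers for stronger inhibition), compound 1 `CN(C)c1nsc(-c2ccc(N3CCN(c4cccc(C(F)(F)F)c4)CC3)nn2)n1` gives 6 nM; 0.4 nM (2 entries), and compound 2 `Cc1nsc(-c2ccc(N3CCN(c4cccc(C#N)c4)CC3)nn2)n1` gives 3 nM. Going by the values given here, that is the only number for compound 2, whose one further entry carries no single number. Compound 3 `Cc1nsc(-c2ccc(N3CCN(c4cc(Cl)cc(Cl)c4)CC3)nn2)n1` has 3,5-dichlorophenyl in place of 3-cyanophenyl on an amine nitrogen in a ring. Among the compounds with values here, no measured step gauges this change, and compound 1 shows wide spread in the several entries of compound 1 in this assay, 6 nM; 0.4 nM (2 entries), so no step beyond the scatter is expected in this assay, and no direction is predicted. The expected change is a 1.3-fold higher number from compound 2 to compound 3 (0.12 log units; within the scatter). For compound 3 the estimate is 4 nM, with an expected range of 0.8 nM to 20 nM.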

Compound 3, half-maximal inhibitory concentration: < 0.1 nM
Compound 3: no number, only a limit; the forecaster's own chance of this, stated with the estimate: 3%; at least 40-fold (1.60 log units) between middle value and limit.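

In this assay, the group on the amine nitrogen in the six-membered ring with 2 nitrogen proves able to move the read-out well beyond the scatter: 3,5-dichlorophenyl in place of 3-cyanophenyl gives an at least 30-fold lower number from compound 2 to compound 3 (1.47 log units; beyond the scatter). Going by these compounds alone, no earlier step had gauged this position. Compound 3 gives < 0.1 nM, which is a limit of the assay and not a number, so this step has no measured upper size.

Going by these compounds, it remains open whether a phenyl ring with a single chlorine would give a similar step, or whether bromine or methyl groups could replace the two chlorines. On these data alone, it is also open whether the step would hold with the other groups on the shared core seen in compound 1.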